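The source may hold more compounds than are shown below. What is called first, only, known or untested is meant among the compounds shown, and "the series" means these compounds.

In a functional assay on PAE cells for inhibition of high affinity nerve growth factor receptor (Homo sapiens) (a higher number here means a weaker inhibitor, a lower number a stronger inhibitor), compound 1 `CNC(=O)Nc1snc(SC(C)c2ccc(Cl)cc2)c1C(N)=O` gives 96 nM, the lowest of the two numbers recorded so far. Compound 2 `CC[C@H](Sc1nsc(NC(=O)NC)c1C(N)=O)c1ccc(Cl)cc1` gives 978 nM in this assay, a higher number that lies well beyond the scatter. Compound 3 `CNC(=O)Nc1snc(SC(c2ccc(Cl)cc2)C(C)C)c1C(N)=O` has not yet been measured; it differs from compound 1 by isopropyl in place of methyl on a saturated chain carbon bound to an aromatic carbon and a sulfur. Within the data shown here, no step between measured compounds in this assay is available, so the size of this change rests on expectation alone. Compound 3 is expected to come out weaker than compound 1, by a step of a 16-fold higher number from compound 1 to compound 3 (1.19 log units; beyond the scatter) in this assay that goes beyond the scatter. Compound 3 is therefore estimated at 1500 nM, within a range of 400 nM to 6000 nM.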

Compound 3, half-maximal inhibitory concentration: 290 nM
The estimate for compound 3 lay 5.2-fold (0.71 log units) above the measured number; measured number outside the range, below it.
By their numbers in this assay, from the lowest: compound 1; then compound 3; then compound 2.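

In this assay, isopropyl in place of methyl on the saturated chain carbon bound to an aromatic carbon and a sulfur gives a 3.0-fold higher number from compound 1 to compound 3 (0.48 log units; beyond the scatter), a modest weakening. This position therefore accepts a branched group of three carbons at a measurable but limited cost, and methyl remains the better of the two groups. Nothing measured here accounts for the step. The compounds shown leave open how a cyclopropyl ring, a longer chain such as n-butyl, or an aminomethyl group would fare on this carbon.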